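The compounds below may be only part of what the source reports. "The series", "measured", "known", "first", "only" and "open" are said of these compounds alone.

Measured in an in vitro ADME assay on microsomes from liver (Rattus norvegicus) for metabolic stability; on this read-out higher numbers stand for fast clearance and lower numbers for slow clearance:
compound 1 `CC(C)NC(=O)[C@H]1CC[C@@H](n2/c(=N/C(=O)c3ccc(C#N)c(F)c3)[nH]c3ccc(CN4CCC(C(C)(C)O)CC4)cc32)CC1`: 29 mL.min-1.g-1
compound 2 `CC(C)NC(=O)[C@H]1CC[C@@H](n2/c(=N/C(=O)c3ccc(F)cc3)[nH]c3ccc(CN4CCC[C@H]4C(C)(C)O)cc32)CC1`: 455 mL.min-1.g-1

Compound 1 holds the lower of these two numbers, and compound 2 lies above it by well beyond the scatter. The two compounds differ in more than one place, so their gap cannot be assigned to any single group.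

Compound 3 `CC(C)NC(=O)[C@H]1CC[C@@H](n2/c(=N/C(=O)c3cc(F)cc(Cl)c3)[nH]c3ccc(CN4CCC(C(C)(C)O)CC4)cc32)CC1` keeps everything in compound 1 except one group: 3-chloro-5-fluorophenyl stands in place of 4-cyano-3-fluorophenyl on a carbonyl carbon (3-chloro-5-fluorophenyl in place of 4-cyano-3-fluorophenyl on a carbonyl carbon). Among the measured compounds shown here, no measured pair isolates this exchange, so any forecast in this assay is uncertain. Compound 1 at 29 mL.min-1.g-1 sits low on a span that reaches up to the number of compound 2, which leaves more room for a rise than for a fall. A small upward move, near the size of the scatter, is expected, and it is estimated as a 1.9-fold higher number from compound 1 to compound 3 (0.28 log units; within the scatter). For compound 3 the expected value is 55 mL.min-1.g-1, with an estimated range from 22 mL.min-1.g-1 to 140 mL.min-1.g-1.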

Compound 3, intrinsic clearance in microsomes: 43 mL.min-1.g-1
For compound 3 the middle estimate is 1.3-fold (0.11 log units) above the measured one, and the stated range covers the measured number.
By their numbers in this assay, from the lowest: compounds 1 and 3 (each within the scatter of the next); then compound 2.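

In this assay, among the compounds shown here, the exchange of 4-cyano-3-fluorophenyl for 3-chloro-5-fluorophenyl on a carbonyl carbon whose other neighbours are an amide-type nitrogen gives a 1.5-fold higher number from compound 1 to compound 3 (0.17 log units; within the scatter), the first step in this set that isolates a single place. It shows that, on the rest of compound 1, this place accepts a group without the nitrile and with chlorine instead, and that the read-out stays within the scatter even though the hydrogen-bond acceptor of the leaving group is gone. No measurement at hand explains why this exchange leaves the read-out within the scatter.

Still open, from the compounds shown here alone, is how the read-out responds to a quite different group on this carbonyl carbon, such as a pyridine ring or a saturated cyclohexyl ring, or to a phenyl ring carrying only the chlorine or only the fluorine. Going by these compounds, it is also open whether this exchange would give a step of the same size if the rest of compound 1 were changed, since the step rests on one pair.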